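Removing the ethyl group from compound 2

The source may report more compounds than this note shows. Statements on the series, on what has been measured and on what is new or still open speak of the compounds shown alone.

In a functional assay on A2780 cells (Homo sapiens) for antiproliferative activity, read by MTT assay, with a stated time of 48 h (a higher number here means a weaker inhibitor, a lower number a stronger inhibitor), compound 2 (`CCNCC(=O)Nc1cc(OC)ccc1C(=O)c1cc(OC)c(OC)c(OC)c1`) stands at 950 nM and compound 1 (`CNCC(=O)Nc1cc(OC)ccc1C(=O)c1cc(OC)c(OC)c(OC)c1`) at 580 nM with no separation beyond the scatter. Compound 3 (`COc1ccc(C(=O)c2cc(OC)c(OC)c(OC)c2)c(NC(=O)CN)c1`) has hydrogen in place of ethyl on an amine nitrogen. For the measured compounds named here, one measured step bears on this change, on the same amine chain: a 1.6-fold higher number from compound 1 to compound 2 (0.21 log units; within the scatter) stays small. No step beyond the scatter is therefore expected in this assay and the estimate is a 1.6-fold lower number from compound 2 to compound 3 (0.20 log units; within the scatter) as the expected step. Compound 3 is estimated at 600 nM with an expected range of 200 nM to 1800 nM for the measurement.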

Compound 3, half-maximal inhibitory concentration: 190 nM
Beside the measured number, compound 3's estimate is 3.2-fold (0.50 log units) above it; measured number below the stated range.
By their numbers in this assay, from the lowest: compound 3; then compounds 1 and 2 (each within the scatter of the next).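

In this assay, hydrogen on the amine nitrogen gives a 5.0-fold lower number from compound 2 to compound 3 (0.70 log units; beyond the scatter), and the same replacement of methyl gives a 3.1-fold lower number from compound 1 to compound 3 (0.48 log units; beyond the scatter). The steps beyond the scatter in this short set are those to the unsubstituted amine, while methyl and ethyl remain within the scatter of each other, so what matters at this nitrogen is whether any alkyl group is present, not which of the two it is. Nothing available explains this separation. Still open, going by these compounds, is whether a dimethylamino group or an acetyl group on this nitrogen would read closer to compound 3 or to compounds 1 and 2.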